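Furan-2-yl Replaces Thiophen-3-yl on the Carbonyl Carbon

The source may report more compounds than this note shows. Statements on the series, on what has been measured and on what is new or still open speak of the compounds shown alone.

Of the compounds shown here, three sharing one core have been tested for inhibition of an assay on isolated protein for inhibition of histone deacetylase HD1B (Zea mays); on this read-out lower numbers stand for stronger inhibition and higher numbers for weaker inhibition. Compound 1 `Cn1cc(/C=C/C(=O)c2ccccc2Cl)cc1/C=C/C(=O)NO` gives 1600 nM. Compound 2 `Cn1cc(/C=C/C(=O)c2cccs2)cc1/C=C/C(=O)NO` gives 25800 nM, and compound 3 `Cn1cc(/C=C/C(=O)c2ccsc2)cc1/C=C/C(=O)NO` gives 22600 nM. Compound 3 stands second highest of the three numbers: its nearest neighbour is compound 2, a 1.1-fold lower number from compound 2 to compound 3 (0.06 log units; within the scatter), while compound 1 lies far away, a 14-fold higher number from compound 1 to compound 3 (1.15 log units; beyond the scatter).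

Compound 4 `Cn1cc(/C=C/C(=O)c2ccco2)cc1/C=C/C(=O)NO` is not yet measured. It differs from compound 3 in one place: furan-2-yl in place of thiophen-3-yl on a carbonyl carbon. The step that bears on it most closely is the exchange of one five-membered aromatic ring for another, a 1.1-fold lower number from compound 2 to compound 3 (0.06 log units; within the scatter), which stayed within the scatter. The large steps, a 16-fold higher number from compound 1 to compound 2 (1.21 log units; beyond the scatter) and a 14-fold higher number from compound 1 to compound 3 (1.15 log units; beyond the scatter), concern the loss of 2-chlorophenyl and do not apply here. Compound 4 is therefore expected to show no step beyond the scatter, a 1.0-fold lower number from compound 3 to compound 4 (0.01 log units; within the scatter). For compound 4 the estimate in this assay is 22000 nM, with a range from 8000 nM to 60000 nM.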

Compound 4, half-maximal inhibitory concentration: 19700 nM
Compound 4: middle estimate off by 1.1-fold (0.05 log units), on the high side; measured number inside the range.
By their numbers in this assay, from the lowest: compound 1; then compounds 4, 3 and 2 (each within the scatter of the next).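

In this assay, furan-2-yl on the carbonyl carbon matches both thiophene isomers, with a 1.1-fold lower number from compound 3 to compound 4 (0.06 log units; within the scatter) and a 1.3-fold lower number from compound 2 to compound 4 (0.12 log units; within the scatter), so exchanging the ring's sulfur for oxygen leaves the read-out within the scatter, whereas the thiophene pair had varied only the point of attachment. The gap to the 2-chlorophenyl group also extends to this third five-membered aromatic ring, with a 12-fold higher number from compound 1 to compound 4 (1.09 log units; beyond the scatter), and it now holds for a ring with a different hetero atom. Nothing available explains why the change of hetero atom has so little effect here.

What the compounds shown leave open is whether the stronger inhibition of compound 1 belongs to its six-membered ring or to its chlorine. A plain phenyl group at this position would separate the two, and an amine on that ring would test whether other substituents can stand in for the chlorine.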